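A few compounds are considered here, and "the series" means these few. Any claim that something is new, unique, unknown or untested is made for them only; others in the source may bear on it.

Measured compounds:
- Compound 1 `CC(C)[C@H]1C(O)=C(C2=NS(=O)(=O)c3c(OCC(N)=O)cccc32)C(=O)N1Cc1ccccc1`; in this assay a limit of the assay, > 1 h
- Compound 2 `CC(C)[C@H]1C(O)=C(C2=NS(=O)(=O)c3c(OCc4ncon4)cccc32)C(=O)N1Cc1ccccc1`; in this assay a limit of the assay, > 1 h
- Compound 3 `CC(C)(C)CCN1C(=O)C(C2=NS(=O)(=O)c3c(OCC(N)=O)cccc32)=C(O)[C@@H]1C(C)(C)C`; in this assay 0.8 h

The three compounds were tested in an in vitro ADME assay on microsomes from liver (Homo sapiens) for metabolic stability; a lower number here means that the compound disappears faster, a higher number that the compound lasts longer. Compound 1 sits at a limit of the assay, > 1 h. Compound 2 also sits at a limit of the assay, > 1 h. The two differ by one change, (1,2,4-oxadiazol-3-yl in place of carbamoyl on a saturated chain carbon bound to an oxygen on an aromatic ring), and the step this makes is a step that the two limits leave unreadable from compound 1 to compound 2 because of the limit of > 1 h in this assay, at which 2 of the 3 values shown sit. Compound 3 is the only one of the three with a real number: in this assay compound 3 gives 0.8 h. Compound 3 and compound 1 share the same change site but differ in more than one place elsewhere; the difference between the two cores is not broken down here.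

Compound 4 `CC(C)(C)CCN1C(=O)C(C2=NS(=O)(=O)c3c(OCc4ncon4)cccc32)=C(O)[C@@H]1C(C)(C)C` has not been measured. It arises from compound 3 by 1,2,4-oxadiazol-3-yl in place of carbamoyl on a saturated chain carbon bound to an oxygen on an aromatic ring, the same change that carries compound 1 to compound 2, at the same place. That earlier step is unreadable. The known pair gives no direction for the new one, and compound 3 itself gives 0.8 h as the only anchor. The step from compound 3 to compound 4 is therefore expected to be small, no change at the digits printed from compound 3 to compound 4 (within the scatter). Compound 4 is estimated to give 0.8 h in this assay, with an expected range from 0.4 h to 1.6 h.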

Compound 4, half-life: 0.733 h
Beside the measured number, compound 4's estimate is 1.1-fold (0.04 log units) above it, and the stated range covers the measured number.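

On the core of compound 3, putting 1,2,4-oxadiazol-3-yl in place of carbamoyl gives, in this assay, a 1.1-fold lower number from compound 3 to compound 4 (0.04 log units; within the scatter), so on this core the two groups cannot be told apart by this read-out. The same change on the core of compound 1 cannot be read, because both compounds of that pair stand at a limit rather than at a number: the limit of > 1 h in this assay, at which 2 of the 4 values shown sit. This gives one readable pair on one core, so it shows that the change can stay within the scatter there, but it does not show that the change behaves the same way on the core of compound 1, and it does not explain why the half-life stays within the scatter.

Still open, as far as these compounds go, is how a carboxylic acid or an amine would read in this assay in place of carbamoyl, on a saturated chain carbon bound to an oxygen on an aromatic ring. Also open, from the compounds shown here alone, are whether a longer chain carrying the 1,2,4-oxadiazol-3-yl group would stay within the scatter of compound 4, and how far apart compound 1 and compound 2 really lie.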